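The source may report more compounds than this note shows. Statements on the series, on what has been measured and on what is new or still open speak of the compounds shown alone.

Measured so far in an ADME assay on microsomes from liver (Mus musculus) for metabolic stability, read by LC-MS, with NADPH named in the record, with a stated time of 60 min, tested at 1 uM, in the absence of a further agent; on this read-out lower numbers stand for a less stable compound and higher numbers for a more stable compound:

- Compound 1 `COc1ccc(-c2c(C)nc3c(N4CC[C@@H](NS(=O)(=O)c5ccc(C)cc5)C4)cc(C)nn23)cc1OC` gives > 95%
- Compound 2 `COc1ccc(-c2c(C)nc3c(N4CC[C@@H](NS(=O)(=O)c5ccc(C(F)(F)F)cc5)C4)cc(C)nn23)cc1OC` gives > 95%

Compound 2 stands at > 95%, which is a limit of the assay and not a number. Compound 1 has a limit too, so neither measured compound has an exact reading, as the record shows with the limit of > 95% in this assay, at which 2 of the 2 values shown sit. For the measured compounds named here, putting trifluoromethyl in place of methyl on an aromatic carbon gives a step that the two limits leave unreadable from compound 1 to compound 2, the only measured step that touches this part of the molecule. It therefore offers no size to carry forward.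

Compound 3 `COc1ccc(-c2c(C)nc3c(N4CC[C@@H](NS(=O)(=O)c5ccc(C(C)=O)cc5)C4)cc(C)nn23)cc1OC` is reached from compound 2 by one further change, (acetyl in place of trifluoromethyl on an aromatic carbon). Here acetyl replaces trifluoromethyl, para to a large group. Acetyl appears in no measured compound, so the data cannot show how it will behave in this assay. The expectation is for no change beyond the usual scatter, while a lower reading remains possible and a wide range stays appropriate. The estimated step is a number at least 5 percentage points lower from compound 2 to compound 3 (that floor lies within the scatter). For compound 3 the expected reading is 90%, with an estimated range of 70% to 100%.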

Compound 3, percent of the compound remaining: > 95%
Compound 3: no number, only a limit (the forecaster's own chance of this, stated with the estimate: 45%); at least 5 percentage points between middle value and limit.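

In this assay compound 3 gives > 95%, which is a limit of the assay and not a number. For the compounds shown here, no step among compound 1, compound 2 and compound 3 can be read, because all three stop at the same limit: the limit of > 95% in this assay, at which 3 of the 3 values shown sit. As far as these compounds go, whether methyl, trifluoromethyl and acetyl differ at all on this read-out stays open.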